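Working notes: from compound 2 to compound 3

This account rests on a few compounds, and the source may have more. Where it says the series, first, only, none or still open, it means among the compounds named here.

Measured so far in a functional assay on blood (Homo sapiens) for inhibition; on this read-out higher numbers stand for weaker inhibition and lower numbers for stronger inhibition
- Compound 1 `O=C(Nc1cccnc1)Oc1ccc(OCc2nc3ccccc3s2)cc1C1(c2ccccc2)CC2CCC1C2` gives 37 nM; 86 nM; 33 nM (3 entries)
- Compound 2 `Oc1ccc(OCc2ccc3ccccc3n2)cc1C1(c2ccccc2)CC2CCC1C2` gives 580 nM

Compound 2 has one number in this assay (580 nM) and one further entry without a number. All entries of compound 1 lie lower (the several entries of compound 1 in this assay, 37 nM; 86 nM; 33 nM (3 entries)).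

Compound 3 `COC(=O)COc1ccc(OCc2ccc3ccccc3n2)cc1C1(c2ccccc2)CC2CCC1C2` is not yet measured. It carries (methoxycarbonyl)methyl in place of hydrogen on an oxygen on an aromatic ring, so hydroxy becomes (methoxycarbonyl)methoxy ((methoxycarbonyl)methyl in place of hydrogen on an oxygen on an aromatic ring).

Among the measured compounds shown here, no measured step covers this change. Compound 1 (37 nM; 86 nM; 33 nM (3 entries)) also has no free hydroxy, but it differs from compound 2 elsewhere too, so it offers only weak support for a moderate move toward stronger inhibition. The expected change is a 1.9-fold lower number from compound 2 to compound 3 (0.29 log units; within the scatter) and remains uncertain. For compound 3 the estimate is 300 nM with an expected range from 80 nM to 1100 nM in this assay.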

Compound 3, half-maximal inhibitory concentration: 290 nM
Beside the measured number, compound 3's estimate is 1.0-fold (0.01 log units) above it, and the stated range covers the measured number.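

On the oxygen on an aromatic ring, (methoxycarbonyl)methyl in place of hydrogen reads in this assay as a 2.0-fold lower number from compound 2 to compound 3 (0.30 log units; within the scatter) and so shows no change beyond the scatter. For this pair, a free hydroxy at this place is therefore not needed to hold the number, and the oxygen accepts a group with 0 hydrogen-bond donors and 5 heavy atoms. Compound 1 differs from compound 3 in more than one place and gives no separate reading of this change.

The compounds shown leave open whether a carboxylic acid or an amine at the end of the chain on this oxygen would give a different number. They also leave open how a longer chain would read, or a simple methyl on the same oxygen.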